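A few compounds are considered here, and "the series" means these few. Any claim that something is new, unique, unknown or untested is made for them only; others in the source may bear on it.

In a functional assay on DMS-273 cells (Homo sapiens) for inhibition, read by colorimetric assay and sulforhodamine B assay, with a stated time of 48 h (a lower number here means a stronger inhibitor of growth, a higher number a weaker inhibitor of growth), compound 1 (`CCCCCCCCCCCC[C@@H](O)[C@H]1CC[C@H]([C@H](O)CCCCCCCCCCNC(=O)c2cccs2)O1`) gives 1820 nM while compound 2 (`CCCCCCCCCCCC[C@@H](O)[C@H]1CC[C@H]([C@H](O)CCCCCCCCCCNC(=O)c2ccco2)O1`) gives 39800 nM as the higher of the two numbers. Compound 3 (`CCCCCCCCCCCC[C@@H](O)[C@H]1CC[C@H]([C@H](O)CCCCCCCCCCNC(=O)c2ccoc2)O1`), not yet measured, differs from compound 2 by furan-3-yl in place of furan-2-yl on a carbonyl carbon and keeps the rest of the molecule. Within the data shown here, the one measured step that bears on this is a 22-fold higher number from compound 1 to compound 2 (1.34 log units; beyond the scatter) and it shows that the ring on the carbonyl carbon can matter, although it exchanges a different pair of groups. A smaller change towards a lower number is therefore expected, namely a 3.3-fold lower number from compound 2 to compound 3 (0.52 log units; beyond the scatter) as an estimate only. In this assay compound 3 is estimated at 12000 nM with an expected range from 2500 nM to 45000 nM once it is measured.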

Compound 3, concentration for 50% growth inhibition: 100000 nM
The estimate for compound 3 lay 8.3-fold (0.92 log units) below the measured number, and the stated range ends below it.
By their numbers in this assay, from the lowest: compound 1; then compound 2; then compound 3.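

Joining the same atoms differently still moves the result: this assay records a 2.5-fold higher number from compound 2 to compound 3 (0.40 log units; beyond the scatter) for furan-3-yl in place of furan-2-yl on a carbonyl carbon, so how the ring is attached matters, not only which hetero atom it holds. The widest gap is a 55-fold higher number from compound 1 to compound 3 (1.74 log units; beyond the scatter) and leaves the thiophen-2-yl amide the strongest of the three. Nothing available explains these differences. On these data alone, whether thiophen-3-yl would follow the furan order remains open, as does whether a phenyl or pyridine ring on that carbonyl carbon would match thiophen-2-yl.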